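A few compounds are considered here, and "the series" means these few. Any claim that something is new, unique, unknown or untested is made for them only; others in the source may bear on it.

Measured so far in an ADME assay on MT4 cells (Homo sapiens) for cytotoxicity, read by MTT assay; on this read-out lower numbers stand for higher toxicity in this test and higher numbers for lower toxicity in this test:
- compound 1 `Cc1cc(C)cc(S(=O)(=O)c2c(C(=O)Nc3ccncc3)[nH]c3ccc(Cl)cc23)c1`: 20200 nM
- compound 2 `Cc1cc(C)cc(S(=O)(=O)c2c(C(=O)NC(C)c3cccnc3)[nH]c3ccc(Cl)cc23)c1`: 54600 nM
- compound 3 `Cc1cc(C)cc(S(=O)(=O)c2c(C(=O)NNc3ccncc3)[nH]c3ccc(Cl)cc23)c1`: 30300 nM

Compound 3 cannot be separated from either of the other two compounds: the data show a 1.5-fold higher number from compound 1 to compound 3 (0.18 log units; within the scatter) and a 1.8-fold lower number from compound 2 to compound 3 (0.26 log units; within the scatter).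

The next compound, compound 4 `Cc1cc(C)cc(S(=O)(=O)c2c(C(=O)NCc3cccs3)[nH]c3ccc(Cl)cc23)c1`, carries (thiophen-2-yl)methyl in place of (pyridin-4-yl)amino on an amide-type nitrogen.

Within the data shown here, all three measured steps are exchanges at this same nitrogen, so they are the only guide to the size of this one. The biggest is a 2.7-fold higher number from compound 1 to compound 2 (0.43 log units; beyond the scatter), which is modest and the only one beyond the scatter. Among the measured compounds shown here, the series therefore shows little movement in this assay across the groups tried at this place so far. For the measured compounds named here, none of the measured compounds carries a thiophene ring, so the direction of the new step has no direct support in the data, and the range is kept wider than the spread of the three numbers.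

No step beyond the scatter is expected, and the estimated step is a 1.1-fold higher number from compound 3 to compound 4 (0.04 log units; within the scatter). For compound 4 the expected value is 33000 nM, with an estimated range of 14000 nM to 75000 nM.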

Compound 4, half-maximal cytotoxic concentration: 54500 nM
Compound 4: middle estimate off by 1.7-fold (0.22 log units), on the low side; measured number inside the range.
By their numbers in this assay, from the lowest: compounds 1, 3, 4 and 2 (each within the scatter of the next, the first and the last beyond it).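

In this assay, among these compounds, the thiophene ring of compound 4 is the first ring at this amide-type nitrogen to carry sulfur and no nitrogen, yet the exchange for (pyridin-4-yl)amino gives only a 1.8-fold higher number from compound 3 to compound 4 (0.25 log units; within the scatter), so a pyridine ring is not required for a number in this range. The exchange for 1-(pyridin-3-yl)ethyl gives a 1.0-fold lower number from compound 2 to compound 4 (0.00 log units; within the scatter), leaving these two groups indistinguishable in this read-out, while the exchange for pyridin-4-yl gives a 2.7-fold higher number from compound 1 to compound 4 (0.43 log units; beyond the scatter), modest and of the same size as a 2.7-fold higher number from compound 1 to compound 2 (0.43 log units; beyond the scatter), so compounds 2 and 4 both stand apart from compound 1, whereas compound 3 cannot be separated from any of the other three. No supporting measurement is available to explain these steps.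

Still open, from the compounds shown here alone, is whether a benzyl or (furan-2-yl)methyl group at this nitrogen would stay in the same range, and whether a longer chain ending in an amine would move the number further. Going by these compounds, all four compounds share the same core, so it also remains open whether these small steps would hold with a group other than the chlorine on that core.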